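The source may hold more compounds than are shown below. What is called first, only, known or untested is meant among the compounds shown, and "the series" means these compounds.

Compound 1 `CC(C(=O)N1CCN(C)CC1)N1CCN(S(=O)(=O)c2ccc(C(C)(C)C)cc2)CC1`: > 40000 nM
Compound 2 `CCC(C)c1ccc(S(=O)(=O)N2CCN(C(C)C(=O)N3CCCC3)CC2)cc1`: > 40000 nM

Both measured compounds were tested in an ADME assay on HepG2 cells (Homo sapiens) for inhibition, with a stated time of 48 h; on this read-out higher numbers stand for an effect only at larger amounts of compound and lower numbers for an effect already at smaller amounts. For compound 1 the value > 40000 nM is a limit of the assay, not a number. For compound 2 the value > 40000 nM is likewise a limit of the assay and not a number. Compound 2 therefore stands where the only other shown value stands, namely at the limit of > 40000 nM in this assay, at which 2 of the 2 values shown sit; no step between two measured compounds can be read from these data.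

Compound 3 `CC(C(=O)N1CCCC1)N1CCN(S(=O)(=O)c2ccc([Si](C)(C)C)cc2)CC1` has not yet been measured. It differs from compound 2 in a single place: a group of 4 heavy atoms (3 carbon, 1 silicon; no ring) in place of a group of 4 heavy atoms (4 carbon; no ring), on an aromatic carbon. In words, a group of 4 heavy atoms, three carbon and one silicon, takes the place of the sec-butyl group on an aromatic carbon.

Since every shown value sits at the limit, there is no measured step to lean on. The expected step here is a number no higher from compound 2 to compound 3 (the limit leaves the size open), which amounts to none beyond the usual scatter of this assay. Compound 3 is accordingly expected to give about 40000 nM in this assay, within 20000 nM to 100000 nM, most probably reported again only as a limit.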

Compound 3, half-maximal effective concentration: > 40000 nM
Compound 3: a limit, no number (the forecaster's own chance of this, stated with the estimate: 80%); the middle value lies on the limit itself.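

Compound 2 and compound 3 each give only a limit of the assay and not a number, so no step between them can be read: the limit of > 40000 nM in this assay, at which 3 of the 3 values shown sit.

The compounds shown leave open what concentration, if any, gives a half-maximal effect in this assay, and whether exchanging the sec-butyl group for the silicon-containing group changes it.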